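Dichlorinated anilino variant of the shared triene core

The source may hold more compounds than are shown below. What is called first, only, known or untested is meant among the compounds shown, and "the series" means these compounds.

Compound 1, `C=C[C@@](C)(/C=C/c1ccc(O)c(/C=C/C#N)c1)CCC=C(C)C`, gives > 52000 nM in a functional assay on HepG2 cells (Homo sapiens) for cytotoxicity, with a stated time of 72 h; on this read-out higher numbers stand for an effect only at larger amounts of compound and lower numbers for an effect already at smaller amounts; this value is a limit of the assay and not a number.
Compound 2, `C=C[C@@](C)(/C=C/c1ccc(Nc2ccccc2)cc1)CCC=C(C)C`, gives > 52000 nM in this assay, again a limit of the assay.
Compound 3, `C=C[C@@](C)(/C=C/c1ccc(Nc2cccc(OC(F)(F)F)c2)cc1)CCC=C(C)C`, gives > 52000 nM in this assay, also a limit of the assay.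

Compound 2 therefore stands at the upper edge of what this assay reports: all three measured values sit there, as the limit of > 52000 nM in this assay, at which 3 of the 3 values shown sit, shows, and none of the three compounds is separated from another by a readable number. Going by the values given here, the one measured step that changes a single place, a step that the two limits leave unreadable from compound 2 to compound 3, is left unreadable by the two limits, so it tells nothing about size or direction.

Compound 4, `C=C[C@@](C)(/C=C/c1ccc(Nc2ccc(Cl)c(Cl)c2)cc1)CCC=C(C)C`, is not yet measured. It differs from compound 2 as follows: 3,4-dichlorophenyl in place of phenyl on a nitrogen on an aromatic ring. No measured step bears directly on this change, and the step from compound 2 to compound 3 is itself unreadable, so no step beyond the scatter can be expected in this assay from the numbers shown. Compound 4 is expected to give 60000 nM, in the range 25000 nM to 150000 nM. The step that the limit leaves unreadable from compound 2 to compound 4 is expected to be within the scatter, with the assay most likely reporting only a limit again.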

Compound 4, half-maximal effective concentration: > 52000 nM
Compound 4 was reported as a limit; the forecaster's own chance of this, stated with the estimate: 80%; the middle value is on the limit's open side.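

In this assay compound 2 and compound 4 both sit at a limit of the assay, so no step from the phenyl to the 3,4-dichlorophenyl variant can be read: the limit of > 52000 nM in this assay, at which 4 of the 4 values shown sit.

The compounds shown leave open at what concentration, if any, each would reach a half-maximal effect on these cells, and whether the change of group alters it.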